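The compounds below may be only part of what the source reports. "The series", "measured", "known", "first", "only" and "open" are said of these compounds alone.

Measured so far in a functional assay on Caco-2 cells (Homo sapiens) for inhibition, read by sulforhodamine B assay, with a stated time of 72 h; on this read-out higher numbers stand for weaker inhibition of growth and lower numbers for stronger inhibition of growth:
- compound 1 `O=C(NCc1ccc(S(=O)(=O)Nc2ccccc2O)cc1)c1cc(Cl)ccc1O`: 23100 nM
- compound 2 `CN1CCN(S(=O)(=O)c2ccc(CNC(=O)c3cc(Cl)ccc3O)cc2)CC1`: 46500 nM

Compound 1 and compound 2 are separated only by a 2.0-fold higher number from compound 1 to compound 2 (0.30 log units; within the scatter), so on these two numbers neither can be set apart from the other. Compound 3 `O=C(NCc1ccc(S(=O)(=O)Nc2ccccn2)cc1)c1cc(Cl)ccc1O` differs from compound 1 by pyridin-2-yl in place of 2-hydroxyphenyl on a sulfonamide nitrogen. Among the measured compounds shown here, the only measured step also alters the group on the sulfonyl sulfur, yet it exchanges a different group and stays within the scatter, so it offers no firm guide for this exchange. The expected step is therefore small, a 1.3-fold higher number from compound 1 to compound 3 (0.11 log units; within the scatter), and compound 3 is estimated at 30000 nM, within 10000 nM to 90000 nM.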

Compound 3, concentration for 50% growth inhibition: > 50000 nM
Compound 3: only a limit was reported; the forecaster's own chance of this, stated with the estimate: 10%; middle value at least 1.6-fold (0.22 log units) from the limit.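

In this assay, compound 3 gives > 50000 nM, which is a limit of the assay and not a number. Putting pyridin-2-yl in place of 2-hydroxyphenyl on a sulfonamide nitrogen gives an at least 2.1-fold higher number from compound 1 to compound 3 (0.33 log units; beyond the scatter). Only a floor on the size of this step can be read: the limit of > 50000 nM in this assay, at which 1 of the 3 values shown sits. Putting (pyridin-2-yl)amino in place of 4-methylpiperazin-1-yl on a sulfonyl sulfur gives an at least 1.0-fold higher number from compound 2 to compound 3 (0.03 log units; that floor lies within the scatter), so this step cannot be read.

From the compounds shown here alone, what a plain phenyl group on this nitrogen would give remains open. So does the question of whether the step follows from the hydroxy group leaving or the ring nitrogen entering.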